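This account rests on a few compounds, and the source may have more. Where it says the series, first, only, none or still open, it means among the compounds named here.

In a functional assay on HeLa cells (Homo sapiens) for antiproliferative activity, read by MTT assay, with a stated time of 48 h (a higher number here means a weaker inhibitor, a lower number a stronger inhibitor), compound 1 `COc1ccc(N(C)c2ccnc(Cl)n2)cc1OCCCCCBr` gives 7090 nM and compound 2 `COc1ccc(N(C)c2ccnc(Cl)n2)cc1OCC[Se]C#N` gives 436 nM. Compound 3 `COc1ccc(N(C)c2cc(C)nc(C)n2)cc1` gives 322 nM, within the scatter of compound 2 and well apart from compound 1. The next structure is compound 4 `COc1ccc(N(C)c2cc(C)nc(C)n2)cc1F`, with fluoro in place of hydrogen on an aromatic carbon. For the measured compounds named here, the only measured step, a 16-fold lower number from compound 1 to compound 2 (1.21 log units; beyond the scatter), is large, but it exchanges one chain end for another on a saturated chain carbon. It therefore gives no guide to a change on an aromatic carbon, and no step beyond the scatter is expected. The expected step in this assay, a 1.0-fold higher number from compound 3 to compound 4 (0.01 log units; within the scatter), stays within the scatter. The estimate for compound 4 is 330 nM, with an expected range from 120 nM to 900 nM.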

Compound 4, half-maximal inhibitory concentration: 471 nM
Compound 4: the middle estimate sits 1.4-fold (0.15 log units) below what was measured; measured number inside the range.
By their numbers in this assay, from the lowest: compounds 3, 2 and 4 (each within the scatter of the next); then compound 1.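

In this assay fluoro in place of hydrogen on an aromatic carbon, ortho to a methoxy group and meta to a large group, gives a 1.5-fold higher number from compound 3 to compound 4 (0.17 log units; within the scatter) and so leaves the number within the scatter. This is the only step shown on an aromatic carbon, so this position tolerates one fluorine atom in this series. Nothing measured here bears on why the step stays this small. As far as these compounds go, whether an amine, a carboxylic acid or a trifluoromethyl group at this position would also stay within the scatter remains open. Also open, from the compounds shown here alone, is whether fluoro behaves alike on the core of compound 2.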